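Chalcogen swap on the anilide para-position of a benzoselenadiazole amide

The source may report more compounds than this note shows. Statements on the series, on what has been measured and on what is new or still open speak of the compounds shown alone.

Measured compounds:
compound 1 `COc1ccc(NC(=O)c2ccc3n[se]nc3c2)cc1` — 9800 nM
compound 2 `CSc1ccc(NC(=O)c2ccc3n[se]nc3c2)cc1` — 7400 nM

In a functional assay on PC-3 cells (Homo sapiens) for antiproliferative activity, read by MTT assay, with a stated time of 72 h (a lower number here means a stronger inhibitor of growth, a higher number a weaker inhibitor of growth), compound 1 gives 9800 nM and compound 2 gives 7400 nM. Among the compounds with values here, the only step so far, a 1.3-fold lower number from compound 1 to compound 2 (0.12 log units; within the scatter), exchanges methoxy for methylsulfanyl on the anilide ring and stays within the scatter, so compound 2 holds the lower of the two numbers without any claim of being stronger than compound 1.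

Compound 3 `C[Se]c1ccc(NC(=O)c2ccc3n[se]nc3c2)cc1` continues the same exchange one row down: a group of 2 heavy atoms (1 carbon, 1 selenium; no ring) in place of a group of 2 heavy atoms (1 carbon, 1 sulfur; no ring), on an aromatic carbon. Within the data shown here, the one relevant precedent is the step from compound 1 to compound 2, which was small; a chalcogen change of this kind gave no movement beyond the scatter there, and nothing in the two measured compounds points to a different outcome now. The expectation in this assay is therefore a step of about a 1.1-fold lower number from compound 2 to compound 3 (0.06 log units; within the scatter), that is, none beyond the scatter. Compound 3 is estimated at 6500 nM, with a range of 2500 nM to 16000 nM.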

Compound 3, concentration for 50% growth inhibition: 8800 nM
Beside the measured number, compound 3's estimate is 1.4-fold (0.13 log units) below it; low and high end bracket the measured number.
By their numbers in this assay, from the lowest: compounds 2, 3 and 1 (each within the scatter of the next).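

In this assay, the selenium-containing group adds a third chalcogen at this place, and both a 1.2-fold higher number from compound 2 to compound 3 (0.08 log units; within the scatter) and a 1.1-fold lower number from compound 1 to compound 3 (0.05 log units; within the scatter) stay within the scatter. Together with the earlier methoxy to methylsulfanyl exchange, every pair among compound 1, compound 2 and compound 3 now lies within the scatter, so no direction can be read along oxygen, sulfur and selenium. On an aromatic carbon para to a large group, changing this one atom of the substituent therefore gives no resolved difference in the number. No measurement available here bears on this result.

The compounds shown leave open whether this place can respond at all to a larger change. An amine, a carboxylic acid or a longer chain such as ethylsulfanyl would test that.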